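The source may hold more compounds than are shown below. What is called first, only, known or untested is meant among the compounds shown, and "the series" means these compounds.

Values below come from a functional assay on HeLa cells (Homo sapiens) for cytotoxicity, read by resazurin assay, with a stated time of 72 h (on this read-out lower numbers stand for stronger inhibition and higher numbers for weaker inhibition), and from no other test.

- compound 1 (`COCCSC(=S)SCC(=O)c1ccc(OC)cc1`) gives 7880 nM
- compound 2 (`CCSC(=S)SCC(=O)c1ccc(C(=O)NCc2ccccc2)s1`) gives 13000 nM

Compound 2 stands within the scatter of compound 1, so these two values establish no order. The two compounds also differ in more than one place, so the pair does not isolate any single structural change.

Compound 3 (`CCSC(=S)SCC(=O)c1ccc(C(=O)N[C@@H](C)c2ccccc2)s1`) departs from compound 2 at one place, with methyl in place of hydrogen on a saturated chain carbon bound to an amide-type nitrogen and an aromatic carbon as the counted difference. In words, this is methyl in place of hydrogen on a saturated chain carbon bound to an amide-type nitrogen and an aromatic carbon, or benzyl to 1-phenylethyl. Within the data shown here, no measured pair covers this change. With that gap, the expectation in this assay is no step beyond the scatter, and neither direction is favoured. The estimated shift is a 1.2-fold lower number from compound 2 to compound 3 (0.07 log units; within the scatter) and would remain small. Compound 3 is expected at 11000 nM with 4500 nM to 27000 nM as the estimated range.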

Compound 3, half-maximal inhibitory concentration: 15800 nM
Estimate against measurement, compound 3: 1.4-fold (0.16 log units) below, within the range that was stated.
By their numbers in this assay, from the lowest: compounds 1, 2 and 3 (each within the scatter of the next).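

Among these compounds, the first comparison that changes only one place, benzyl to 1-phenylethyl, reads in this assay as a 1.2-fold higher number from compound 2 to compound 3 (0.08 log units; within the scatter) and so gives a first direct reading of this position. Methyl in place of hydrogen on the saturated chain carbon bound to the amide-type nitrogen and the aromatic carbon leaves the cytotoxicity read-out within the scatter, so this position accepts the one added carbon, in the configuration drawn for compound 3, with no measurable shift in this assay. No available evidence bears on the reason for this outcome.

Going by these compounds, it remains open whether a longer chain such as ethyl, or a carboxylic acid, on that same saturated chain carbon would carry the number beyond the scatter, and whether the mirror-image form of compound 3 would read like compound 3. Among the compounds shown here, the single step also leaves open whether the same methyl would behave alike on another core, such as that of compound 1, which differs from compound 2 in more than one place.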